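From Propyl to Hydroxy on the Aromatic Ring

The compounds below may be only part of what the source reports. "The series", "measured", "known", "first", "only" and "open" are said of these compounds alone.

Of the compounds shown here, three built on one shared core have numbers so far. In a functional assay on PC-3 cells (Homo sapiens) for inhibition, read by sulforhodamine B assay, with a stated time of 48 h (a lower number here means a stronger inhibitor of growth, a higher number a weaker inhibitor of growth), compound 1 (`CCOC(=O)C1=C(C)NC(=O)NC1c1ccc(SC)cc1`), which carries methylsulfanyl, gives 9.5 ug/mL as its result. Compound 2 (`CCOC(=O)C1=C(C)NC(=O)NC1c1ccc(O)c(O)c1`) gives 18.2 ug/mL and compound 3 (`CCCc1ccc(C2NC(=O)NC(C)=C2C(=O)OCC)cc1`), which carries propyl, gives 25 ug/mL and these last two values lie within the usual scatter of each other. Within the data shown here, the one clear gap around compound 3 is a 2.6-fold higher number from compound 1 to compound 3 (0.42 log units; beyond the scatter) and it is modest, though beyond the scatter.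

Compound 4 (`CCOC(=O)C1=C(C)NC(=O)NC1c1ccc(O)cc1`) has no number yet. It carries hydroxy in place of propyl on an aromatic carbon para to a large group. Among the measured compounds shown here, no measured step makes this exact change. The step with propyl entering at that place, a 2.6-fold higher number from compound 1 to compound 3 (0.42 log units; beyond the scatter), shows only that this position can move the number modestly. Compound 2 also carries hydroxy there, and its 18.2 ug/mL stays within the scatter of compound 3. Only a step within the scatter is therefore expected in this assay and the estimated move is a 1.4-fold lower number from compound 3 to compound 4 (0.14 log units; within the scatter) in all. For compound 4 the expected value is 18 ug/mL with an estimated range from 8 ug/mL to 40 ug/mL as its upper end.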

Compound 4, concentration for 50% growth inhibition: 136 ug/mL
Estimate against measurement, compound 4: 7.6-fold (0.88 log units) below; measured number outside the range, above it.
By their numbers in this assay, from the lowest: compounds 1, 2 and 3 (each within the scatter of the next, the first and the last beyond it); then compound 4.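

Among these compounds, the hydroxy group on its own at this place, para to a large group, gives a far weaker inhibitor of growth in this assay than the earlier compounds suggested: replacing propyl gives a 5.4-fold higher number from compound 3 to compound 4 (0.74 log units; beyond the scatter), and replacing methylsulfanyl gives a 14-fold higher number from compound 1 to compound 4 (1.16 log units; beyond the scatter), the only step here large enough to be rated large. The step from the compound with two hydroxy groups shows that the effect depends on more than the hydroxy at this place, since hydrogen in place of the other hydroxy on an aromatic carbon gives a 7.5-fold higher number from compound 2 to compound 4 (0.87 log units; beyond the scatter), so a hydroxy at this place does not by itself set a high number. Nothing available explains why these steps are so large.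

The compounds shown leave open whether the high number of compound 4 is specific to hydroxy or would also appear with an amine or a methoxy group at this place. They also leave open whether a longer chain than propyl would move the number in this assay at all, or whether a carboxylic acid there would behave as hydroxy does.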